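The source may hold more compounds than are shown below. What is called first, only, known or untested is meant among the compounds shown, and "the series" means these compounds.

In an assay on HEK293 cells for inhibition of solute carrier family 22 member 12 (Homo sapiens), read by scintillation counting, with a stated time of 12 min (on this read-out higher numbers stand for weaker inhibition and lower numbers for stronger inhibition), compound 3 `O=C(O)C1(Sc2ccnc3ccc(-c4ccccc4F)cc23)CCC1` gives 333 nM. Of the two compounds with a number, compound 3 stands highest, yet its nearest neighbour is compound 1 `COCCOc1ccc2nccc(SC3(C(=O)O)CCC3)c2c1`, which in this assay gives 207 nM, and the step of a 1.6-fold higher number from compound 1 to compound 3 (0.21 log units; within the scatter) lies within the scatter. Compound 2 `CNC(=O)COc1ccc2nccc(SC3(C(=O)O)CCC3)c2c1` reaches only a limit of this assay, > 10000 nM. The two large steps seen so far, an at least 48-fold higher number from compound 1 to compound 2 (1.68 log units; beyond the scatter) and an at least 30-fold lower number from compound 2 to compound 3 (1.47 log units; beyond the scatter), both involve that limit of > 10000 nM in this assay, at which 1 of the 3 values shown sits, and concern the exchange of the whole group on the aromatic carbon, not the position of a fluorine within a phenyl ring.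

Compound 4 `O=C(O)C1(Sc2ccnc3ccc(-c4ccc(F)cc4)cc23)CCC1` differs from compound 3 by 4-fluorophenyl in place of 2-fluorophenyl on an aromatic carbon. Within the data shown here, no measured step moves a substituent around an attached phenyl ring, so none bears directly on this change; the only step that touches the same aromatic carbon, from compound 1 to compound 3, was within the scatter. The step of a 1.1-fold higher number from compound 3 to compound 4 (0.02 log units; within the scatter) is therefore expected to stay within the scatter. Compound 4 is estimated at 350 nM, with a range from 120 nM to 1100 nM.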

Compound 4, half-maximal inhibitory concentration: 159 nM
The estimate for compound 4 lay 2.2-fold (0.34 log units) above the measured number; low and high end bracket the measured number.
By their numbers in this assay, from the lowest: compounds 4, 1 and 3 (each within the scatter of the next, the first and the last beyond it). At a limit, above all of these: compound 2.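

In this assay, where the fluorine sits on the attached phenyl ring now registers: 4-fluorophenyl in place of 2-fluorophenyl, two groups with the same heavy atoms, gives a 2.1-fold lower number from compound 3 to compound 4 (0.32 log units; beyond the scatter), a modest step beyond the scatter. Against 2-methoxyethoxy on the same aromatic carbon, the 4-fluorophenyl group shows a 1.3-fold lower number from compound 1 to compound 4 (0.11 log units; within the scatter), so these two groups cannot be told apart here. The step of an at least 62-fold lower number from compound 2 to compound 4 (1.79 log units; beyond the scatter) is only a bound, as the value of compound 2 is a limit: the limit of > 10000 nM in this assay, at which 1 of the 4 values shown sits.

From the compounds shown here alone, whether the fluorine itself matters stays open, as a plain phenyl or a chlorophenyl group on this carbon would be needed to judge it. Going by these compounds, it is equally open how an amine or a longer chain carrying a carboxylic acid would behave at this position.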